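The source may hold more compounds than are shown below. What is called first, only, known or untested is meant among the compounds shown, and "the series" means these compounds.

Compound 1 `O=C(Nc1cccc2cccnc12)c1cccnn1` in a functional assay on BXPC-3 cells (Homo sapiens) for inhibition, read by MTT assay, with a stated time of 72 h (on this read-out higher numbers stand for weaker inhibition and lower numbers for stronger inhibition), gives > 10000 nM, a limit of the assay. Compound 2 `O=C(Nc1cccc2cccnc12)c1ncccn1` gives > 10000 nM, also a limit. Compound 3 `Cc1ccc2cccc(NC(=O)c3ncccn3)c2n1` gives > 10000 nM, again a limit.

Compound 2 thus stands at the limit, as do the other two values, which is the limit of > 10000 nM in this assay, at which 3 of the 3 values shown sit. The steps reaching it and leaving it, a step that the two limits leave unreadable from compound 1 to compound 2 and a step that the two limits leave unreadable from compound 2 to compound 3, are unreadable in size. Compound 4 `NCCOc1cc(NC(=O)c2ncccn2)c2ncccc2c1` differs from compound 2 by 2-aminoethoxy in place of hydrogen on an aromatic carbon. Among the measured compounds shown here, no measured step resembles this change, and none is readable, so there is no basis for expecting a step in either direction beyond the scatter. For compound 4 the estimated step is a step that the limit leaves unreadable from compound 2 to compound 4. Compound 4 is expected to give 12000 nM, between 2000 nM and 50000 nM, most likely again as a limit.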

Compound 4, half-maximal inhibitory concentration: > 10000 nM
Compound 4 gave a limit, no number; the forecaster's own chance of this, stated with the estimate: 60%; the middle value is on the limit's open side.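

Among the compounds shown here, compound 2 and compound 4 both give only a limit, so no step between them can be read. The compounds shown leave open whether any change to the shared core gives a readable number in this assay at all.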